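Benzyl in place of 3,4-dihydroxyphenyl on the oxygen

The source may report more compounds than this note shows. Statements on the series, on what has been measured and on what is new or still open speak of the compounds shown alone.

In a functional assay on HL-60 cells (Homo sapiens) for inhibition, read by CCK-8 assay, with a stated time of 48 h (a higher number here means a weaker inhibitor, a lower number a stronger inhibitor), compound 1 `O=C(NCCNS(=O)(=O)c1ccc(-c2ccccc2O[C@H]2CC[C@@H](O)CC2)s1)Nc1cc(C(F)(F)F)cc(C(F)(F)F)c1` gives 3100 nM and compound 2 `O=C(NCCNS(=O)(=O)c1ccc(-c2ccccc2Oc2ccc(O)c(O)c2)s1)Nc1cc(C(F)(F)F)cc(C(F)(F)F)c1` gives 10500 nM, the highest of the two numbers. Compound 3 `O=C(NCCNS(=O)(=O)c1ccc(-c2ccccc2OCc2ccccc2)s1)Nc1cc(C(F)(F)F)cc(C(F)(F)F)c1` carries benzyl in place of 3,4-dihydroxyphenyl on an oxygen on an aromatic ring. Going by the values given here, the only measured step at this oxygen, 3,4-dihydroxyphenyl in place of 4-hydroxycyclohexyl, is a 3.4-fold higher number from compound 1 to compound 2 (0.53 log units; beyond the scatter), modest and beyond the scatter. Resting on that single step, a similarly modest move towards compound 1 is expected, a 2.1-fold lower number from compound 2 to compound 3 (0.32 log units; beyond the scatter). Compound 3 is estimated at 5000 nM, with an expected range of 1800 nM to 14000 nM.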

Compound 3, half-maximal inhibitory concentration: 11400 nM
For compound 3 the middle estimate is 2.3-fold (0.36 log units) below the measured one, and the stated range covers the measured number.
By their numbers in this assay, from the lowest: compound 1; then compounds 2 and 3 (each within the scatter of the next).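

In this assay, benzyl and 3,4-dihydroxyphenyl on this oxygen cannot be told apart (a 1.1-fold higher number from compound 2 to compound 3 (0.04 log units; within the scatter)), so this change, which removes the hydroxyl groups of 3,4-dihydroxyphenyl, leaves the number within the scatter. Benzyl stays apart from 4-hydroxycyclohexyl (a 3.7-fold higher number from compound 1 to compound 3 (0.57 log units; beyond the scatter)), so compound 1 now has the lowest number by a margin beyond the scatter against both aromatic groups. Still open, going by these compounds, is whether that margin needs the hydroxyl of 4-hydroxycyclohexyl or only the cyclohexyl ring; plain cyclohexyl or 4-aminocyclohexyl on the same oxygen would separate the two. No evidence accounts for these differences.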